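A few compounds are considered here, and "the series" means these few. Any claim that something is new, unique, unknown or untested is made for them only; others in the source may bear on it.

In a functional assay on L1210 cells (Mus musculus) for inhibition (a lower number here means a stronger inhibitor, a higher number a weaker inhibitor), compound 1 `Nc1ncnc2c1ncn2C/C=C/CCl` gives 45000 nM and compound 2 `Nc1ncnc2c1ncn2C/C=C\CCl` gives 22000 nM. Compound 3 `Nc1ncnc2c1ncn2/C=C\CCO` has the highest number of the three at 200000 nM, which makes it the weakest inhibitor here. Compound 4 `Nc1ncnc2c1ncn2/C=C/CCO` relates to compound 3 simply: the two compounds have the same atoms and bonds and differ only in configuration as drawn: 1 of 1 stereo elements differ; a double bond is drawn Z in compound 3 and E in compound 4. The closest guide is a 2.0-fold lower number from compound 1 to compound 2 (0.31 log units; beyond the scatter), which can be put down to configuration because of the fact that compounds 1 and 2 differ only in the configuration as drawn. The chain there is 4-chlorobut-2-en-1-yl, not 4-hydroxybut-1-en-1-yl, so the guide is only partial. Read in reverse, from Z to E, that modest step points to a modest rise in the number. The expected change is a 1.5-fold higher number from compound 3 to compound 4 (0.18 log units; within the scatter). For compound 4 the estimated value is 300000 nM, with an expected range of 130000 nM to 650000 nM.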

Compound 4, half-maximal inhibitory concentration: 100000 nM
Compound 4: middle estimate off by 3.0-fold (0.48 log units), on the high side; measured number below the stated range.
By their numbers in this assay, from the lowest: compound 2; then compound 1; then compounds 4 and 3 (each within the scatter of the next).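

With 4-hydroxybut-1-en-1-yl as the chain, changing the configuration gives a 2.0-fold lower number from compound 3 to compound 4 (0.30 log units; within the scatter), so this Z and E pair cannot be told apart, unlike the chlorinated pair: the fact that compounds 3 and 4 differ only in the configuration as drawn

Changing the chain, by contrast, stays beyond the scatter in this assay, with a 2.2-fold higher number from compound 1 to compound 4 (0.35 log units; beyond the scatter) and a 4.5-fold higher number from compound 2 to compound 4 (0.66 log units; beyond the scatter).

Still open, from the compounds shown here alone, is which part of that chain change matters, the hydroxy group replacing chlorine or the shifted double bond, as the two always travel together here. Going by these compounds, how an amine or a longer chain would read in this place also remains open.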